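Methoxycarbonyl to ethylcarbamoyl on a clearance scale

A few compounds are considered here, and "the series" means these few. Any claim that something is new, unique, unknown or untested is made for them only; others in the source may bear on it.

In an in vitro ADME assay on microsomes from liver (Rattus norvegicus) for metabolic stability (on this read-out lower numbers stand for slow clearance and higher numbers for fast clearance), compound 2 (`COC(=O)[C@H]1CC[C@@H](n2/c(=N/C(=O)c3ccccc3)[nH]c3ccc(CN4CCCCC4)cc32)CC1`) stands at the top of the numbers, giving 459 mL.min-1.g-1 as the highest value. Compound 1 (`CC(C)NC(=O)[C@H]1CC[C@@H](n2/c(=N/C(=O)c3ccc(C#N)c(F)c3)[nH]c3ccc(CN4CCC(C(C)(C)O)CC4)cc32)CC1`) gives 29 mL.min-1.g-1 in this assay, a gap to compound 2 that lies well beyond the scatter. Compound 3 (`CC(C)NC(=O)[C@H]1CC[C@@H](n2/c(=N/C(=O)c3ccc(F)cc3)[nH]c3ccc(CN4CC(C(C)(C)O)C4)cc32)CC1`) is reported at < 14 mL.min-1.g-1 and this is a limit of the assay, not a number. Among the compounds with values here, compound 1 and compound 3 each differ from compound 2 in more than one place, so no measured step isolates a single change.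

Compound 4 (`CCNC(=O)[C@H]1CC[C@@H](n2/c(=N/C(=O)c3ccccc3)[nH]c3ccc(CN4CCCCC4)cc32)CC1`) keeps the rest of compound 2 and alters one group: ethylamino in place of methoxy on a carbonyl carbon, with ethylamino in place of methoxy on a carbonyl carbon. Like compound 4, compound 1 (29 mL.min-1.g-1) has a nitrogen rather than methoxy on that carbonyl carbon, though it also differs elsewhere. A fall in this assay is therefore expected, beyond the scatter but smaller than the whole gap separating compound 2 from compound 1. The expected change is a 3.5-fold lower number from compound 2 to compound 4 (0.55 log units; beyond the scatter) in this estimate. Compound 4 is estimated at 130 mL.min-1.g-1 in this assay, with an expected range from 50 mL.min-1.g-1 to 320 mL.min-1.g-1 for the measurement to come.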

Compound 4, intrinsic clearance in microsomes: 310 mL.min-1.g-1
Compound 4: the middle estimate sits 2.4-fold (0.38 log units) below what was measured, within the range that was stated.
By their numbers in this assay, from the lowest: compound 1; then compounds 4 and 2 (each within the scatter of the next). At a limit, below all of these: compound 3.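

In this assay, within the data shown here, the exchange of methoxy for ethylamino on a carbonyl carbon, seen here on its own for the first time, gives a 1.5-fold lower number from compound 2 to compound 4 (0.17 log units; within the scatter), so at this position methoxycarbonyl and ethylcarbamoyl cannot be told apart on this read-out. The earlier compounds shown here could not show this, since compound 1 and compound 3 also carry a nitrogen on that carbonyl carbon but differ from compound 2 in other places as well, which left open how much of the gap belonged to this change. Compound 4 shows that this single change, on the otherwise unchanged structure of compound 2, does not by itself account for the far smaller clearance numbers of compound 1, and nothing reported here gives a reason for the size of the step.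

Going by these compounds, whether a carboxylic acid, a dimethylamino group or a longer chain on the same carbonyl carbon would behave like ethylamino remains open. Among these compounds, also open is which of the other places where compound 1 and compound 3 depart from compound 4 matters for clearance, as no single step isolates any of them.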